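Adding a second methoxy to compound 2

A few compounds are considered here, and "the series" means these few. Any claim that something is new, unique, unknown or untested is made for them only; others in the source may bear on it.

Measured compounds:
Compound 1 `c1ccc(-c2ccc(-c3ccc(-c4nc5ccccc5[nH]4)cc3)cc2)cc1`: 100000 nM
Compound 2 `COc1ccc(-c2ccc(-c3ccc(-c4nc5ccccc5[nH]4)cc3)cc2)cc1`: 100000 nM

In a functional assay on DWD cells (Homo sapiens) for inhibition, read by sulforhodamine B assay (a higher number here means a weaker inhibitor of growth, a lower number a stronger inhibitor of growth), compound 2 gives 100000 nM, level with compound 1 at the digits reported. The next compound to be measured is compound 3 `COc1ccc(-c2ccc(-c3ccc(-c4nc5ccccc5[nH]4)cc3)cc2)cc1OC`, which differs from compound 2 as follows: methoxy in place of hydrogen on an aromatic carbon. The same difference, cut one bond further out, turns 4-methoxyphenyl into 3,4-dimethoxyphenyl.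

Within the data shown here, only one measured step bears on this change. It is also methoxy in place of hydrogen on an aromatic carbon, and it shows no change at the digits printed from compound 1 to compound 2 (within the scatter). That step placed its methoxy on a bare ring, so the data do not show what a second methoxy, ortho to a methoxy group, does. One step is thin evidence, and no measured compound in this short series has yet shown a value away from this level. No step beyond the scatter is therefore expected in this assay, although a shift towards a lower number cannot be excluded. The expected change is a 1.1-fold lower number from compound 2 to compound 3 (0.05 log units; within the scatter). For compound 3 the estimate is 90000 nM, with an expected range of 25000 nM to 100000 nM.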

Compound 3, concentration for 50% growth inhibition: 42100 nM
For compound 3 the middle estimate is 2.1-fold (0.33 log units) above the measured one, and the stated range covers the measured number.
By their numbers in this assay, from the lowest: compound 3; then compounds 1 and 2 (each within the scatter of the next).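

In this assay the second methoxy, ortho to a methoxy group and meta to a large group, gives a 2.4-fold lower number from compound 2 to compound 3 (0.38 log units; beyond the scatter) and so does what the first methoxy did not, since that one, placed on a bare ring, gave no change at the digits printed from compound 1 to compound 2 (within the scatter) in the same read-out. Among these compounds, measured against the unsubstituted end of the series, 3,4-dimethoxyphenyl in place of phenyl gives a 2.4-fold lower number from compound 1 to compound 3 (0.38 log units; beyond the scatter) and makes compound 3 the only compound here whose number stands apart from the level shared by compound 1 and compound 2, so a methoxy at this position can move the number in this assay when the neighbouring methoxy is already present. No measurement at hand accounts for why the second methoxy shifts the number when the first did not.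

The compounds shown leave open whether this methoxy would shift the number on its own, meta to a large group and without the methoxy ortho to it, or only as part of the pair. They also leave open what a hydroxy group, an amine or a longer chain such as ethoxy would do on the same aromatic carbon.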